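A Sulfur Ring Gives Way to One Oxygen Atom

The source may hold more compounds than are shown below. What is called first, only, known or untested is meant among the compounds shown, and "the series" means these compounds.

- compound 1 `O=c1[nH]c(=O)n([C@H]2C[C@H](O)[C@@H](CO)O2)cc1CO` gives 9180 nM in an ADME assay on L1210/0 cells (Mus musculus) for cytotoxicity, with a stated time of 48 h; a lower number here means a stronger inhibitor, a higher number a weaker inhibitor
- compound 2 `CCCC#Cc1cn([C@H]2C[C@H](O)[C@@H](CO)O2)c(=O)[nH]c1=O` gives > 200000 nM in this assay
- compound 3 `O=c1[nH]c(=O)n([C@H]2C[C@H](O)[C@@H](CO)O2)cc1C1SCCS1` gives > 200000 nM in this assay

Compound 3 gives only a limit (> 200000 nM) and no number. Compound 2 likewise gives only a limit (> 200000 nM) and no number. Both sit at the same limit (the limit of > 200000 nM in this assay, at which 2 of the 3 values shown sit), and the step between them cannot be read (a step that the two limits leave unreadable from compound 2 to compound 3).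

Compound 4 `O=c1[nH]c(=O)n([C@H]2C[C@H](O)[C@@H](CO)O2)cc1O` has not yet been measured, and its difference from compound 3 is one oxygen atom on an aromatic carbon (one oxygen atom in place of a group of 5 heavy atoms (3 carbon, 2 sulfur; one five-membered non-aromatic ring with 2 hetero atoms), on an aromatic carbon). Among the compounds with values here, two measured steps bear on this change. Both lead away from the hydroxymethyl group of compound 1 (9180 nM) to a group of 5 heavy atoms, and both are large (an at least 21-fold higher number from compound 1 to compound 2 (1.33 log units; beyond the scatter); an at least 21-fold higher number from compound 1 to compound 3 (1.33 log units; beyond the scatter)). The change to compound 4 runs the other way, so a large move to a lower number is expected, although a reading at the limit remains possible. For compound 4 the expected step is an at least 6.6-fold lower number from compound 3 to compound 4 (0.82 log units; beyond the scatter) in this assay overall. For compound 4 the estimated value is 30000 nM with an expected range from 6000 nM to 200000 nM in this assay overall.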

Compound 4, half-maximal inhibitory concentration: > 200000 nM
Compound 4 ended at the assay's limit; the forecaster's own chance of this, stated with the estimate: 25%; middle value at least 6.6-fold (0.82 log units) from the limit.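

Until now, only groups of 5 heavy atoms on this aromatic carbon had led away from the measurable value of compound 1. Compound 4 shows that hydroxy does the same, with an at least 21-fold higher number from compound 1 to compound 4 (1.33 log units; beyond the scatter). Compound 2, compound 3 and compound 4 each give only a limit, so the steps among them cannot be read, and hydroxymethyl remains the only group shown here that gives a number in this assay, with the other three compounds sharing one limit: the limit of > 200000 nM in this assay, at which 3 of the 4 values shown sit.

Going by these compounds, how compound 2, compound 3 and compound 4 rank among themselves stays open. On these data alone, it also stays open whether a methyl group, an aminomethyl group or a longer hydroxyalkyl chain on this carbon would give a number in this assay.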